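Swapping the benzyl halogens on compound 2

The source may report more compounds than this note shows. Statements on the series, on what has been measured and on what is new or still open speak of the compounds shown alone.

Compound 1 `CC(C)CN(CC(C)C)N1CCN(c2nc(=O)c3cc(C(F)(F)F)cc([N+](=O)[O-])c3s2)CC1` — in an ADME assay on Vero cells (Chlorocebus sabaeus) for cytotoxicity, read by MTT assay, with a stated time of 72 h (on this read-out higher numbers stand for lower toxicity in this test and lower numbers for higher toxicity in this test), compound 1 gives > 64 ug/mL, which is a limit of the assay.
Compound 2 `O=c1nc(N2CCN(NCc3cc(F)cc(F)c3)CC2)sc2c([N+](=O)[O-])cc(C(F)(F)F)cc12` — in this assay compound 2 gives > 64 ug/mL, which is likewise a limit of the assay.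

Compound 2 therefore stands only at a limit, with no number of its own. The step that the two limits leave unreadable from compound 1 to compound 2 cannot be sized, because both of its ends are limits (the limit of > 64 ug/mL in this assay, at which 2 of the 2 values shown sit). Compound 3 `O=c1nc(N2CCN(NCc3ccc(Cl)cc3)CC2)sc2c([N+](=O)[O-])cc(C(F)(F)F)cc12` differs from compound 2 by 4-chlorophenyl in place of 3,5-difluorophenyl on a saturated chain carbon bound to an amine nitrogen. Among the compounds with values here, the only measured step bearing on this change is the unreadable one from compound 1 to compound 2, so no direction or size can be drawn from it; what both measured values show is that they sit at the limit (the limit of > 64 ug/mL in this assay, at which 2 of the 2 values shown sit). Compound 3 is accordingly expected to remain at that limit, an expected step that the limit leaves unreadable from compound 2 to compound 3. The estimate for compound 3 in this assay is 80 ug/mL, within 40 ug/mL to 160 ug/mL.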

Compound 3, half-maximal cytotoxic concentration: > 64 ug/mL
Compound 3: a limit, no number; the forecaster's own chance of this, stated with the estimate: 80%; the middle value is on the limit's open side.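

In this assay compound 3 also stands at a limit of the assay, so no step to compound 3 from compound 1 or compound 2 can be read: the limit of > 64 ug/mL in this assay, at which 3 of the 3 values shown sit.

The compounds shown leave open whether compound 1, compound 2 and compound 3 differ at all in cytotoxicity, and what replacing the 3,5-difluorobenzyl with 4-chlorobenzyl does to it.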